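This account rests on a few compounds, and the source may have more. Where it says the series, first, only, none or still open, it means among the compounds named here.

Measured compounds and their numbers:
compound 1, `CCOC(=O)C1=C(C)NC(C)=C(C(=O)OCC)C1c1ccc(OCC(=O)Nc2nc3ccccc3s2)cc1`, 65.9%
compound 2, `CCOC(=O)C1=C(C)NC(C)=C(C(=O)OCC)C1c1ccc(OCC(=O)NNC(=O)c2ccccc2)cc1`, 44.9%
compound 3, `CCOC(=O)C1=C(C)NC(C)=C(C(=O)OCC)C1c1ccc(OCC(=O)NNC(=O)c2ccsc2Cl)cc1`, 53.3%

All three were tested in a functional assay on the whole organism (strain Wistar) for inhibition, with Rattus norvegicus as the target, read by paw edema, with stated times of 30 min and 3 h, at a dose of 20 mg/kg; on this read-out lower numbers stand for less inhibition and higher numbers for more inhibition at the one dose given (going by the name of the read-out). Compound 3 stands second highest of the three: one neighbouring step is a number 8.4 percentage points higher from compound 2 to compound 3 (within the scatter), so those two cannot be told apart, while the other step is a number 12.6 percentage points lower from compound 1 to compound 3 (beyond the scatter).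

Compound 4 is `CCOC(=O)C1=C(C)NC(C)=C(C(=O)OCC)C1c1ccc(OCc2nnc(S)o2)cc1`. Relative to compound 3 the change is a group of 6 heavy atoms (2 carbon, 2 nitrogen, 1 oxygen, 1 sulfur; one five-membered aromatic ring with 3 hetero atoms) in place of a group of 12 heavy atoms (6 carbon, 2 nitrogen, 2 oxygen, 1 sulfur, 1 chlorine; one five-membered aromatic ring with 1 hetero atom), on a saturated chain carbon bound to an oxygen on an aromatic ring. Among the measured compounds shown here, no measured step touches this place; the known steps, a number 21 percentage points lower from compound 1 to compound 2 (beyond the scatter) and a number 12.6 percentage points lower from compound 1 to compound 3 (beyond the scatter), swapped groups on the amide-type nitrogen, and all three numbers lie in a fairly narrow band. With no guide for this change, compound 4 is expected to stay near that band, at an estimated 50% with a range from 32% to 68%, an expected step of a number 3.3 percentage points lower from compound 3 to compound 4 (within the scatter).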

Compound 4, a percentage reported as inhibition, in the whole organism at one dose (the size of the read-out at that dose, not a potency): 61.1%
For compound 4 the middle estimate is 11.1 percentage points below the measured one; low and high end bracket the measured number.
By their numbers in this assay, from the lowest: compounds 2, 3, 4 and 1 (each within the scatter of the next, the first and the last beyond it).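

Among the compounds shown here, this is the first change at the saturated chain carbon bound to an oxygen on an aromatic ring, and in this assay the 5-sulfanyl-1,3,4-oxadiazol-2-yl group gives a number 7.8 percentage points higher from compound 3 to compound 4 (within the scatter) and a number 4.8 percentage points lower from compound 1 to compound 4 (within the scatter), with neither step separating the pair, but a number 16.2 percentage points higher from compound 2 to compound 4 (beyond the scatter). A group of 6 heavy atoms can therefore take the place of larger amide-type groups here without a loss beyond the scatter. No measurement shown gives a reason for this.

On these data alone, what an amine or a methyl group in place of the sulfanyl would do remains open. So does how these compounds would rank at a second dose.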